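The source may hold more compounds than are shown below. What is called first, only, known or untested is meant among the compounds shown, and "the series" means these compounds.

Measured compounds in an ADME assay on HepAD38 cells (Homo sapiens) for cytotoxicity, read by MTT assay, with a stated time of 7 days; on this read-out lower numbers stand for higher toxicity in this test and higher numbers for lower toxicity in this test:
compound 1 `COc1ccc(Cc2nc(SC3CCCCCC3)[nH]c(=O)c2I)cc1OC` gives 98000 nM
compound 2 `O=c1[nH]c(SCCOc2ccc([N+](=O)[O-])cc2)nc(Cn2nnc3ccccc32)c1I` gives 52000 nM

Compound 1 holds the higher of the two numbers in this assay , but compound 2 lies within the usual scatter of it, so the two cannot be separated on this read-out; both sit at the low-toxicity end of the half-maximal cytotoxic concentration scale.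

Compound 3 `COc1ccc(Cc2nc(SCc3cccc(Cl)c3)[nH]c(=O)c2I)cc1OC` is not yet measured. It keeps the core of compound 1 and differs only in the group on the sulfur: 3-chlorobenzyl in place of cycloheptyl on a sulfur. Going by the values given here, the two compounds measured so far share no such change, so there is no measured step to lean on; the only guidance is that compound 1 and compound 2, which differ widely on that sulfur, show numbers within the scatter of each other.

On that basis no step beyond the scatter is expected, with at most a slight drift to a lower number; the estimated step of a 1.4-fold lower number from compound 1 to compound 3 (0.15 log units; within the scatter) is taken as small. For compound 3 the expected half-maximal cytotoxic concentration in this assay is 70000 nM, with a range from 25000 nM to 200000 nM.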

Compound 3, half-maximal cytotoxic concentration: 119000 nM
Compound 3: middle estimate off by 1.7-fold (0.23 log units), on the low side, within the range that was stated.
By their numbers in this assay, from the lowest: compounds 2, 1 and 3 (each within the scatter of the next, the first and the last beyond it).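

On the sulfur whose other neighbour is an aromatic carbon, 3-chlorobenzyl in place of cycloheptyl gives a 1.2-fold higher number from compound 1 to compound 3 (0.08 log units; within the scatter) in this assay, the only step among the compounds shown in which the rest of the structure is held fixed. On the core of compound 1, this read-out therefore does not separate a seven-membered non-aromatic ring of carbon only from the six-membered aromatic ring of 3-chlorobenzyl, although the exchange replaces one ring type with the other and brings in a chlorine. No accompanying measurement bears on this result, and the step is recorded here as an observation only.

On these data alone, whether an amine, a carboxylic acid or a longer carbon chain on the same sulfur would give a step beyond the scatter in this assay remains open. Also open, as far as these compounds go, is whether the exchange of cycloheptyl for 3-chlorobenzyl would give a similar step on a core other than that of compound 1, since this single pair cannot show how far the result extends.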